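Replacing the Pyridyl Group in Compound 3

A few compounds are considered here, and "the series" means these few. Any claim that something is new, unique, unknown or untested is made for them only; others in the source may bear on it.

Compound 1 `Cc1ccnc(/C(N)=N/NC(=S)N2CCSCC2)c1` gives 74.2% in a functional assay on MCF7 cells (Homo sapiens) for cytotoxicity, read by MTT assay, with a stated time of 72 h, tested at 30 uM; on this read-out higher numbers stand for more inhibition of growth at the one concentration tested and lower numbers for less inhibition of growth.
Compound 2 `N/C(=N\NC(=S)N1CCOCC1)c1ccc(F)cn1` gives 56.7% in this assay.
Compound 3 `N/C(=N\NC(=S)N1CCN(c2ccccn2)CC1)c1ccc(F)cn1` gives 58.6% in this assay.

Among these three numbers compound 3 stands second highest in this assay: its gap to compound 2 lies within the usual scatter, while compound 1 sits beyond the scatter above it. Compound 4 `Cc1ccnc(/C(N)=N/NC(=S)N2CCN(c3ccccn3)CC2)c1` is not yet measured. It differs from compound 3 in one place: 4-methylpyridin-2-yl in place of 5-fluoropyridin-2-yl on a carbon with a double bond to nitrogen. Going by the values given here, no measured pair differs in exactly this way; compound 1 and compound 2 differ at two places, so their values alone cannot isolate the pyridyl swap. A modest upward step is expected in this assay, a number 6.4 percentage points higher from compound 3 to compound 4 (within the scatter), though the change may also fall within the scatter. Compound 4 is estimated at 65%, between 50% and 80%.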

Compound 4, percent growth inhibition at one concentration: 63.8%
Beside the measured number, compound 4's estimate is 1.2 percentage points above it; the measured number falls inside the stated range.
By their numbers in this assay, from the lowest: compounds 2, 3 and 4 (each within the scatter of the next); then compound 1.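

Going by these compounds alone, with the rest of the molecule unchanged, 4-methylpyridin-2-yl in place of 5-fluoropyridin-2-yl gives a number 5.2 percentage points higher from compound 3 to compound 4 (within the scatter) in this assay, the first step that isolates this place on the carbon with a double bond to nitrogen. The step lies within the scatter, so this swap shows no clear effect on growth inhibition. Nothing here gives a reason for this result. On these data alone, whether an amine or a carboxylic acid on the pyridyl group would move the number beyond the scatter remains open. So does whether the same swap would give a similar step with the other end of compound 2.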